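The source may hold more compounds than are shown below. What is called first, only, known or untested is meant among the compounds shown, and "the series" means these compounds.

Working notes on the series. Compound 1 `O=C(O)CCc1ccc(NCc2cccc(C(F)(F)F)c2)cc1`, compound 2 `O=C(O)CCc1ccc(OCc2cccc(C(F)(F)F)c2)cc1` and compound 3 `O=C(O)CCc1ccc(OCc2cccc(-c3ccccc3)c2)cc1` have been measured in a functional assay on 1321-N1 cells for agonist activity at Free fatty acid receptor 1 (Homo sapiens), read by calcium flux; on this read-out higher numbers stand for larger maximal responses and lower numbers for smaller maximal responses; compound 4 `O=C(O)CCc1ccc(NCc2cccc(-c3ccccc3)c2)cc1` has not. In this assay compound 1 gives 102%, compound 2 gives 103% and compound 3 gives 105%; all three lie within the scatter of one another, so no order is drawn among them. How the core of compound 1 differs from the core of compound 2 is not broken down here. From compound 2 to compound 3 the change is phenyl in place of trifluoromethyl on an aromatic carbon, and it brought a number 2 percentage points higher from compound 2 to compound 3 (within the scatter). The same change is made from compound 1 to compound 4, (phenyl in place of trifluoromethyl on an aromatic carbon), at the same place on the ring. The expected step is a number 2 percentage points higher from compound 1 to compound 4 (within the scatter), sized like the earlier one, because a number 2 percentage points higher from compound 2 to compound 3 (within the scatter) stayed within the scatter and the maximal responses seen so far sit close together. Compound 4 is therefore expected at 104% in this assay. The expected range for compound 4 runs from 94% to 114%.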

Compound 4, largest response reached (reported as efficacy), in percent of the reference or control that the assay uses: 101%
Compound 4: middle estimate off by 3 percentage points, on the high side; the range from low to high includes it.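

In this assay, phenyl in place of trifluoromethyl on an aromatic carbon gave a number 1 percentage points lower from compound 1 to compound 4 (within the scatter), so on the core of compound 1, as on the core of compound 2, this change produced no step beyond the scatter. The two steps do not differ once the scatter of two such steps is allowed for: the same change on two cores in this assay, a number 2 percentage points higher (within the scatter) from compound 2 to compound 3 and a number 1 percentage points lower (within the scatter) from compound 1 to compound 4, 3 percentage points apart, within the scatter of two such steps. This shows that, for these two cores and at this one place, the change carries over without a detectable difference in maximal response, but it does not show that the steps are identical, and it gives no basis for extending the result to other cores, or for reading the maximal response as a guide to the concentration needed for a response.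

As far as these compounds go, whether the maximal response stays this close with a nitrile or a methoxy group at the same place remains open. Also open, from the compounds shown here alone, is whether it stays this close with a longer chain carrying the carboxylic acid.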